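Butoxy in place of benzyl: compound 2 to compound 4

The source may report more compounds than this note shows. Statements on the series, on what has been measured and on what is new or still open speak of the compounds shown alone.

For the measured compounds named here, compound 2 `Nc1nn(C(=O)Nc2ccc(Cc3ccccc3)cc2)c2ccccc12` carries the benzyl group; in a functional assay on SK-OV-3 cells (Homo sapiens) for inhibition, read by sulforhodamine B assay, with a stated time of 48 h (a lower number here means a stronger inhibitor of growth, a higher number a weaker inhibitor of growth), compound 2 gives 36900 nM, the only numeric value in the set. Compound 1 `O=C(Nc1ccc(Cc2ccccc2)cc1)Nc1nn(C(=O)Nc2ccc(Cc3ccccc3)cc2)c2ccccc12` reaches only a limit in this assay, > 100000 nM. Compound 3 `COc1ccc(NC(=O)Nc2n[nH]c3ccccc23)cc1` likewise stops at a limit, > 100000 nM. Two of the three values thus sit at the limit of > 100000 nM in this assay, at which 2 of the 3 values shown sit. Compound 4 `CCCCOc1ccc(NC(=O)n2nc(N)c3ccccc32)cc1` differs from compound 2 by butoxy in place of benzyl on an aromatic carbon, para to a large group. Going by the values given here, no measured step in the set bears on this change, so no direction is supported; a step within the scatter is the expectation, with a limit possible. Compound 4 is expected to give 45000 nM, between 12000 nM and 150000 nM. The step from compound 2 to compound 4 is estimated at a 1.2-fold higher number from compound 2 to compound 4 (0.09 log units; within the scatter).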

Compound 4, concentration for 50% growth inhibition: 44000 nM
Compound 4: middle estimate off by 1.0-fold (0.01 log units), on the high side, and the stated range covers the measured number.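

In this assay, for the compounds shown here, the first step that can be read at this place, on an aromatic carbon para to a large group, is a 1.2-fold higher number from compound 2 to compound 4 (0.08 log units; within the scatter). Butoxy in place of benzyl removes the six-membered aromatic ring and brings in an oxygen, yet the number stays within the scatter, so this position accepts a ringless chain as readily as benzyl. Nothing at hand gives a cause for this step. The compounds shown leave open whether a hexyloxy chain, an amine or a carboxylic acid at this place would move the number beyond the scatter. With a single step, no trend across this position can be drawn.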